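Swapping fluorophenyl for trihydroxyphenyl on a thioether enone

The compounds below may be only part of what the source reports. "The series", "measured", "known", "first", "only" and "open" are said of these compounds alone.

Measured so far:
compound 1, `CC(=O)Oc1ccc(/C=C(\C(=O)c2ccc(Cl)cc2)S(=O)(=O)c2ccc(C)cc2)cc1`, 25000 nM
compound 2, `Cc1ccc(CS/C(=C/c2ccccc2F)C(=O)c2ccc(Cl)cc2)cc1`, 10000 nM
compound 3, `Cc1ccc(CS(=O)(=O)/C(=C/c2c(O)cc(O)cc2O)C(=O)c2ccc(Cl)cc2)cc1`, > 100000 nM

All three were tested in a functional assay on DU-145 cells (Homo sapiens) for inhibition, read by trypan blue exclusion, with a stated time of 96 h; a lower number here means a stronger inhibitor of growth, a higher number a weaker inhibitor of growth. Compound 2 gives 10000 nM, the lowest of the two numbers recorded. Compound 1 gives 25000 nM, a higher number, and this gap lies beyond the scatter. Compound 3 reaches only a limit of the assay, > 100000 nM, so no number is known for it.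

Compound 4, `Cc1ccc(CS/C(=C/c2c(O)cc(O)cc2O)C(=O)c2ccc(Cl)cc2)cc1`, has not yet been measured. It differs from compound 2 in one place: 2,4,6-trihydroxyphenyl in place of 2-fluorophenyl on a double-bonded chain carbon bound to a double-bonded chain carbon. Among the compounds with values here, no pair of measured compounds differs by exactly this change, so the step must be judged from what is at hand. Compound 3 carries the same 2,4,6-trihydroxyphenyl and sits at the limit of > 100000 nM in this assay, at which 1 of the 3 values shown sits, whereas its partner compound 1 gives a number, which points toward weaker growth inhibition when this ring is present.

Weaker inhibition than that of compound 2 is therefore expected. For compound 4 the estimate is 50000 nM, with a range from 15000 nM to 150000 nM. The expected step is a 5.0-fold higher number from compound 2 to compound 4 (0.70 log units; beyond the scatter), with a real chance that only a limit is reported.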

Compound 4, concentration for 50% growth inhibition: 50000 nM
Compound 4: the middle estimate sits on the measured number at the digits printed; measured number inside the range.
By their numbers in this assay, from the lowest: compound 2; then compounds 1 and 4 (each within the scatter of the next). At a limit, above all of these: compound 3.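

Replacing 2-fluorophenyl with 2,4,6-trihydroxyphenyl on a double-bonded chain carbon bound to a double-bonded chain carbon now has a measured size on the thioether: in this assay the change gives a 5.0-fold higher number from compound 2 to compound 4 (0.70 log units; beyond the scatter). This step lies beyond the scatter, so growth inhibition does respond to the ring at this place, yet compound 4 still returns a number, 50000 nM. Compound 3, which carries the same ring, gives no number and stands at a limit of the assay: the limit of > 100000 nM in this assay, at which 1 of the 4 values shown sits.

Going by these compounds, whether the change reflects gaining the hydroxyl groups or losing the fluorine stays open, as this single step cannot separate the two. Also open, on these data alone, is how other rings would behave at this place, such as plain phenyl or 2,4,6-trimethoxyphenyl.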